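This account rests on a few compounds, and the source may have more. Where it says the series, first, only, none or still open, it means among the compounds named here.

Of the compounds shown here, three built on one shared core have been tested in a functional assay on the whole organism (strain Holtzman) with Rattus norvegicus as the target; on this read-out lower numbers stand for an effect already at smaller amounts and higher numbers for an effect only at larger amounts of compound. Compound 2 `Cc1nn(C)c2c1C(c1ccccc1)=NCC(=O)N2` gives 10 mg/kg, the lowest of the two plain numbers. Compound 3 `Cc1nn(C)c2c1C(c1cccs1)=NCC(=O)N2` gives 40 mg/kg in this assay. For compound 1 `Cn1ncc2c1NC(=O)CN=C2c1ccccc1` the assay reports only a limit, > 80 mg/kg, and not a number. Two steps connect them: an at least 8.0-fold lower number from compound 1 to compound 2 (0.90 log units; beyond the scatter), and a 4.0-fold higher number from compound 2 to compound 3 (0.60 log units; beyond the scatter). Compound 4 `Cc1nn(C)c2c1C(c1ccccc1Cl)=NCC(=O)N2` has not been measured yet; it differs from compound 2 by chloro in place of hydrogen on an aromatic carbon. Neither measured step adds a chloro group to a phenyl ring, so they bear only loosely on this change, though the step to compound 3 shows that altering the ring on the carbon with a double bond to nitrogen can move the number beyond the scatter. For compound 4 a modest shift at most is expected, a 2.0-fold lower number from compound 2 to compound 4 (0.30 log units; within the scatter). Compound 4 is estimated at 5 mg/kg, within 1.5 mg/kg to 20 mg/kg.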

Compound 4, minimum effective dose: 2.5 mg/kg
Estimate against measurement, compound 4: 2.0-fold (0.30 log units) above; the measured number falls inside the stated range.
By their numbers in this assay, from the lowest: compound 4; then compound 2; then compound 3. At a limit, above all of these: compound 1.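

In this assay, a change on the phenyl ring itself lowers the number: chloro on an aromatic carbon ortho to a large group gives a 4.0-fold lower number from compound 2 to compound 4 (0.60 log units; beyond the scatter). Going by these compounds alone, the only earlier change at this ring, thiophen-2-yl in place of phenyl, had raised the number, so this part of the molecule can move the dose in either direction. Nothing shown here explains why chloro has this effect. As far as these compounds go, whether fluoro, methoxy or an amine at this place would also lower the number remains open. So does the effect of chloro on the other carbons of the ring.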